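Adding a second chloro to compound 3

A few compounds are considered here, and "the series" means these few. Any claim that something is new, unique, unknown or untested is made for them only; others in the source may bear on it.

compound 1 `COc1ccc(/C=C2\CN(C)C/C(=C\c3ccccc3F)C2=O)cc1`: 23500 nM
compound 2 `CN1C/C(=C\c2ccc(C#N)cc2)C(=O)/C(=C/c2ccccc2F)C1`: 1340 nM
compound 3 `COc1cc(/C=C2\CN(C)C/C(=C\c3ccc(Cl)cc3)C2=O)cc(OC)c1`: 11200 nM

All three compounds were tested in a functional assay on HeLa cells (Homo sapiens) for cytotoxicity, read by MTT assay, with a stated time of 24 h; a lower number here means a stronger inhibitor, a higher number a weaker inhibitor. In this test, compound 3 gives 11200 nM, the middle number of the three. It lies closer to compound 1 than to compound 2, and its gap to each is beyond the usual scatter.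

Compound 4 `COc1cc(/C=C2\CN(C)C/C(=C\c3ccc(Cl)c(Cl)c3)C2=O)cc(OC)c1` turns the 4-chlorophenyl of compound 3 into a 3,4-dichlorophenyl: chloro in place of hydrogen on an aromatic carbon. The new chloro stands ortho to the existing chloro group.

Going by the values given here, only one measured step is available, and it is a different kind of change. The large step of an 18-fold lower number from compound 1 to compound 2 (1.24 log units; beyond the scatter) puts cyano in place of methoxy. Among the compounds with values here, it shows that one substituent swap can move the number strongly here, but no measured step adds a chloro. A modest move towards a lower number is therefore expected, possibly not beyond the scatter, and the direction is uncertain.

The expected step is a 1.5-fold lower number from compound 3 to compound 4 (0.17 log units; within the scatter).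

For compound 4 the estimated value is 7500 nM, with an expected range of 3000 nM to 16000 nM.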

Compound 4, half-maximal inhibitory concentration: 6900 nM
Compound 4: middle estimate off by 1.1-fold (0.04 log units), on the high side; the measured number falls inside the stated range.
By their numbers in this assay, from the lowest: compound 2; then compounds 4 and 3 (each within the scatter of the next); then compound 1.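

In this assay, going by these compounds alone, the change from 4-chlorophenyl to 3,4-dichlorophenyl gives a 1.6-fold lower number from compound 3 to compound 4 (0.21 log units; within the scatter) and this is the first measured step that adds a chloro to an aromatic carbon. At this position, ortho to the existing chloro group, the added atom leaves the two compounds within the usual scatter of each other, unlike an 18-fold lower number from compound 1 to compound 2 (1.24 log units; beyond the scatter) for the swap of methoxy to cyano. No measurement here bears on why the added chloro changes the number so little.

On these data alone, whether an amine or a carboxylic acid at this same position would move the number beyond the scatter remains open. Also open, as far as these compounds go, is whether a second chloro placed elsewhere on this ring would behave in the same way.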